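The source may hold more compounds than are shown below. What is called first, only, known or untested is meant among the compounds shown, and "the series" means these compounds.

Within the data shown here, in an ADME assay on NIH3T3 cells (Mus musculus) for cytotoxicity (a higher number here means that more compound is tolerated, a lower number that less compound is tolerated), compound 2 `CN1CCN(CC#Cc2ccc3ncnc(Nc4ccc(OCc5cccc(F)c5)c(Cl)c4)c3c2)CC1` gives 7.2 uM, the only exact number so far. Compound 3 `Fc1cccc(COc2ccc(Nc3ncnc4ccc(C#CC5CCCC5)cc34)cc2Cl)c1` is still unmeasured and has cyclopentyl in place of (4-methylpiperazin-1-yl)methyl on a triple-bonded carbon. Among the measured compounds shown here, no measured pair shows this change directly. Compound 1 `CC(C)(C)CC#Cc1cc2c(Nc3ccc(OCc4cccc(F)c4)c(Cl)c3)ncnc2s1`, whose core differs and which also has a carbon-only group on its triple bond, reports only a limit, > 50 uM. On that single comparison, a clear rise beyond the scatter is expected, meaning more compound tolerated, and the estimated change is a 3.9-fold higher number from compound 2 to compound 3 (0.59 log units; beyond the scatter). Compound 3 is estimated at 28 uM, within an expected range of 10 uM to 50 uM.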

Compound 3, half-maximal toxic concentration: > 50 uM
Compound 3 was reported as a limit; the forecaster's own chance of this, stated with the estimate: 40%; middle value at least 1.7-fold (0.25 log units) from the limit.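

Among these compounds, compound 3 gives the first direct comparison at this position. On the shared core, cyclopentyl in place of (4-methylpiperazin-1-yl)methyl on a triple-bonded carbon gives, in this assay, an at least 6.9-fold higher number from compound 2 to compound 3 (0.84 log units; beyond the scatter). The value of compound 3 is a limit and not a number, so this step marks only a minimum: the limit of > 50 uM in this assay, at which 2 of the 3 values shown sit.

Going by these compounds, how much higher the true number lies stays open. On these data alone, it is also open whether a smaller amine in the same place, such as dimethylaminomethyl, would behave like cyclopentyl or like (4-methylpiperazin-1-yl)methyl.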